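Removing the tert-butoxycarbonyl tail from a weakly binding series

The source may hold more compounds than are shown below. What is called first, only, known or untested is meant among the compounds shown, and "the series" means these compounds.

Measured compounds:
Compound 1 `CC[C@H](C)[C@H](NC(=O)c1cccc(Cn2ccnc2)c1)C(=O)NNS(=O)(=O)c1ccccc1` gives 6% in an assay on HEK293 cells for displacement of a labelled ligand from Type-2 angiotensin II receptor (Homo sapiens), tested at 1 uM; on this read-out lower numbers stand for a weaker effect and higher numbers for a stronger effect at the one concentration tested.
Compound 2 `CC[C@H](C)[C@H](NC(=O)c1cccc(Cn2ccnc2)c1)C(=O)NNS(=O)(=O)c1c(C)cc(C)cc1C` gives 10%.
Compound 3 `CC[C@H](C)[C@H](NC(=O)c1cccc(Cn2ccnc2)c1)C(=O)NNC(=O)OC(C)(C)C` gives "not determined" (no result reported) in this assay.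

Compounds 1 and 2 share one core and differ only at the sulfonyl sulfur; the step of a number 4 percentage points higher from compound 1 to compound 2 (within the scatter) shows that this change leaves the read-out essentially unchanged, with both compounds weak. Compound 3 carries the same core but ends in a (tert-butoxycarbonyl)amino group; it stands nowhere on the numbers, since no value was reported. Compound 4 `CC[C@H](C)[C@H](NC(=O)c1cccc(Cn2ccnc2)c1)C(N)=O` arises from compound 3 by the change (hydrogen in place of (tert-butoxycarbonyl)amino on an amide-type nitrogen). Within the data shown here, no measured step touches this part of the molecule, so the only guide is that every measured relative is weak in this assay. Compound 4 is therefore expected to stay weak, estimated at 6% with a range from -4% to 18%.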

Compound 4, a percentage reported as inhibition, at one concentration (the size of the read-out at that concentration, not a potency): "not active" (no number reported)
Compound 4 has no reported number here, and the estimate cannot be compared.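

Neither compound 3 nor compound 4 has a reported number, so no step can be read between them, and nothing shown here offers an explanation. As far as these compounds go, what losing the (tert-butoxycarbonyl)amino group does in this assay stays open.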